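This account rests on a few compounds, and the source may have more. Where it says the series, first, only, none or still open, it means among the compounds named here.

Measured so far:
compound 1 `COc1ccc(-c2c(-c3cc(OC)c(OC)c(OC)c3)noc2NC(C)=O)cc1OC`: 17700 nM
compound 2 `COc1cc(-c2noc(NC(C)=O)c2-c2ccc(Cl)cc2)cc(OC)c1OC`: 9530 nM
compound 3 `COc1ccc(-c2c(-c3cc(OC)c(OC)c(OC)c3)noc2N(C(C)=O)C(C)=O)cc1OC`: > 50000 nM

All values come from a functional assay on ECa-109 cells (Homo sapiens) for cytotoxicity, read by MTT assay, with a stated time of 48 h; a higher number here means a weaker inhibitor, a lower number a stronger inhibitor. Compound 1 and compound 2 differ by 4-chlorophenyl in place of 3,4-dimethoxyphenyl on an aromatic carbon, and the step between them is a 1.9-fold lower number from compound 1 to compound 2 (0.27 log units; within the scatter). The two cores differ as acetyl in place of hydrogen on an amide-type nitrogen, with a step of an at least 2.8-fold higher number from compound 1 to compound 3 (0.45 log units; beyond the scatter). For compound 3 the assay reports only a limit, (the limit of > 50000 nM in this assay, at which 1 of the 3 values shown sits). Compound 4 `COc1cc(-c2noc(N(C(C)=O)C(C)=O)c2-c2ccc(Cl)cc2)cc(OC)c1OC` has not been measured in this assay; it differs from compound 3 by 4-chlorophenyl in place of 3,4-dimethoxyphenyl on an aromatic carbon. The surroundings of the place are not identical: in compound 1 the carbon is next to the ring atom that bears an acetamido group (4 heavy atoms), in compound 3 it is next to the ring atom that bears a diacetylamino group (7 heavy atoms), so this is the same kind of change, not the same change. The expected step is a step that the limit leaves unreadable from compound 3 to compound 4, resting on compound 1 and compound 2 and their small a 1.9-fold lower number from compound 1 to compound 2 (0.27 log units; within the scatter). Compound 4 is therefore expected to give about 60000 nM, somewhere from 25000 nM to 150000 nM, and the assay may well report only a limit again.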

Compound 4, half-maximal inhibitory concentration: 39800 nM
Beside the measured number, compound 4's estimate is 1.5-fold (0.18 log units) above it; the range from low to high includes it.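

In this assay, 4-chlorophenyl in place of 3,4-dimethoxyphenyl gives an at least 1.2-fold lower number from compound 3 to compound 4 (0.09 log units; that floor lies within the scatter), a floor rather than a full step, to be set against the same change on the acetamido cores: the same change on two cores in this assay, a 1.9-fold lower number (0.27 log units; within the scatter) from compound 1 to compound 2 and an at least 1.2-fold lower number (0.09 log units; that floor lies within the scatter) from compound 3 to compound 4; the limit leaves it open whether they differ. Acetyl in place of hydrogen on the amide-type nitrogen gives a 4.2-fold higher number from compound 2 to compound 4 (0.62 log units; beyond the scatter), which runs in the same direction on both cores: the same change on two cores in this assay, an at least 2.8-fold higher number (0.45 log units; beyond the scatter) from compound 1 to compound 3 and a 4.2-fold higher number (0.62 log units; beyond the scatter) from compound 2 to compound 4; the limit leaves it open whether they differ. Compound 3 is reported only as a limit, so the direction of the acetyl step carries from one core to the other, but equal size on the two cores is not shown for either change, and the aryl change is not shown to exceed the scatter on either core: the limit of > 50000 nM in this assay, at which 1 of the 4 values shown sits.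

The compounds shown leave open how a free amine or a longer acyl chain in place of the acetamido group would read in this assay. Also open, going by these compounds, is how a fluorine or a nitrile in place of the chlorine of the 4-chlorophenyl group would read there.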